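Oxazole for triazole on the urea side chain

A few compounds are considered here, and "the series" means these few. Any claim that something is new, unique, unknown or untested is made for them only; others in the source may bear on it.

Measured compounds:
compound 1 `CCOC(=O)c1ccc(NC(=O)NCc2c[nH]nn2)cc1` — 7750 nM
compound 2 `O=C(NCc1ccncc1)Nc1ccc(S(=O)(=O)N2CC3CCC(C2)O3)cc1` — 279 nM

Compound 1 and compound 2 were tested in an assay on isolated protein for activation of Nicotinamide phosphoribosyltransferase (Homo sapiens); a higher number here means that more compound is needed for the effect, a lower number that less compound is needed. Compound 1 has the highest of the two numbers: compound 2, its nearest neighbour, shows a number well below it, and that gap lies beyond the usual scatter. The two share only the urea, so their gap cannot be tied to any single change.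

Compound 3 `CCOC(=O)c1ccc(NC(=O)NCc2cnco2)cc1` is not yet measured. It differs from compound 1 in one place: 1,3-oxazol-5-yl in place of 1H-1,2,3-triazol-4-yl on a saturated chain carbon bound to an amide-type nitrogen. Among the measured compounds shown here, no measured pair shows this exact exchange, so the step has no precedent here. Without a parallel the expectation rests on the shared core of compound 1, and the step of a 1.0-fold higher number from compound 1 to compound 3 (0.01 log units; within the scatter) is expected to stay within the scatter, in no clear direction. Compound 3 is therefore estimated at 8000 nM, with a range from 2500 nM to 25000 nM.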

Compound 3, half-maximal effective concentration: 6900 nM
The estimate for compound 3 lay 1.2-fold (0.06 log units) above the measured number; low and high end bracket the measured number.
By their numbers in this assay, from the lowest: compound 2; then compounds 3 and 1 (each within the scatter of the next).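

In this assay, placing 1,3-oxazol-5-yl in place of 1H-1,2,3-triazol-4-yl on a saturated chain carbon bound to an amide-type nitrogen gives a 1.1-fold lower number from compound 1 to compound 3 (0.05 log units; within the scatter) and so leaves the two compounds indistinguishable. The exchange takes away the hydrogen-bond donor of the ring, yet the number stays within the scatter, so on this core that donor is not needed to keep the number where it stands. Nothing measured here explains why the two rings read alike.

As far as these compounds go, both groups are five-membered aromatic rings, so it remains open whether a carboxylic acid, an amine or a plain longer chain in their place would shift the number. From the compounds shown here alone, it is also open whether the same exchange would read alike on a different core.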